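From Methoxy to Ethoxy on a Shared Core

A few compounds are considered here, and "the series" means these few. Any claim that something is new, unique, unknown or untested is made for them only; others in the source may bear on it.

In a functional assay on HL-60 cells (Homo sapiens) for inhibition, read by resazurin assay, with a stated time of 72 h (a lower number here means a stronger inhibitor, a higher number a weaker inhibitor), compound 3 `COc1ccc(C2CC(=O)N2c2cc(OC)c(OC)c(OC)c2)cc1` gives 76 nM. Compound 1 `COc1cc(N2C(=O)CC2c2ccc(SC)cc2)cc(OC)c1OC` gives 69 nM, within the scatter of compound 3. Compound 2 `CCOc1ccc(C2C(Oc3ccccc3)C(=O)N2c2cc(OC)c(OC)c(OC)c2)cc1` gives 494 nM, clearly a weaker result than compound 3. Compound 4 `CCOc1ccc(C2CC(=O)N2c2cc(OC)c(OC)c(OC)c2)cc1` changes compound 3 in one place: methyl in place of hydrogen on a saturated chain carbon bound to an oxygen on an aromatic ring, so that methoxy becomes ethoxy. Among the measured compounds shown here, no measured pair shows this change alone. The closest evidence is a 1.1-fold higher number from compound 1 to compound 3 (0.04 log units; within the scatter), where methoxy replaces methylsulfanyl on an aromatic carbon. That swap made no difference beyond the scatter, so a similarly small effect is expected here in this assay, with any drift slightly upward. The expected step is a 1.3-fold higher number from compound 3 to compound 4 (0.12 log units; within the scatter). For compound 4 the estimate is 100 nM, with an expected range of 40 nM to 280 nM.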

Compound 4, half-maximal inhibitory concentration: 88 nM
Estimate against measurement, compound 4: 1.1-fold (0.06 log units) above; low and high end bracket the measured number.
By their numbers in this assay, from the lowest: compounds 1, 3 and 4 (each within the scatter of the next); then compound 2.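

In this assay, the step from methoxy to ethoxy gives a 1.2-fold higher number from compound 3 to compound 4 (0.06 log units; within the scatter) and ethoxy in place of methylsulfanyl gives a 1.3-fold higher number from compound 1 to compound 4 (0.11 log units; within the scatter), so the number holds across all three groups on this shared core. Hydrogen in place of phenoxy on a saturated ring carbon gives a 5.6-fold lower number from compound 2 to compound 4 (0.75 log units; beyond the scatter), so the weaker number of compound 2 goes with phenoxy and not with ethoxy. Nothing given here explains these results.

Still open, from the compounds shown here alone, is whether a longer chain such as propoxy would hold the number as ethoxy does. Going by these compounds, an amine in place of ethoxy is equally open.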